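From a Hydroxymethylphenyl to a Nitrophenyl Analogue

The source may hold more compounds than are shown below. What is called first, only, known or untested is meant among the compounds shown, and "the series" means these compounds.

Compound 1 `O=c1ccc2cc(OCc3cc(-c4cccc([N+](=O)[O-])c4)no3)ccc2o1` — 48300 nM
Compound 2 `O=c1ccc2cc(OCc3cn(-c4cccc(CO)c4)nn3)ccc2o1` — "not determined" (no result reported)

Compound 1 was tested in a functional assay on COLO 205 cells (Homo sapiens) for cytotoxicity, read by MTT assay, with a stated time of 48 h (a lower number here means a stronger inhibitor, a higher number a weaker inhibitor), and gave 48300 nM, a weak result. Within the data shown here, for compound 2 the outcome in this assay is "not determined" (no result reported), so compound 2 stands on no single number at all, and no step between measured compounds can be drawn from this pair.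

Compound 3 `O=c1ccc2cc(OCc3cn(-c4ccc([N+](=O)[O-])cc4)nn3)ccc2o1` differs from compound 2 by 4-nitrophenyl in place of 3-(hydroxymethyl)phenyl on an aromatic nitrogen. Among the measured compounds shown here, with no measured step to lean on, the expectation for this change rests on compound 1 alone, which carries a nitrophenyl group on the shared core and gave 48300 nM. No direction for the move from compound 2 to compound 3 can be claimed beyond the scatter; a weak inhibitor in the range of compound 1 is the plain expectation. Compound 3 is therefore estimated at 40000 nM in this assay, with a range from 10000 nM to 150000 nM.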

Compound 3, half-maximal inhibitory concentration: 48700 nM
Compound 3: middle estimate off by 1.2-fold (0.09 log units), on the low side; low and high end bracket the measured number.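

No step can be read from compound 2 to compound 3, as compound 2 has no value in this assay to set against. The compounds shown leave open what 4-nitrophenyl in place of 3-(hydroxymethyl)phenyl does to the result. No supporting evidence bears on the value of compound 3.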